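Benzyl for Cyclohexyl on the Ring Nitrogen of Compound 2

The source may report more compounds than this note shows. Statements on the series, on what has been measured and on what is new or still open speak of the compounds shown alone.

Of the compounds shown here, three sharing one core have been measured in a functional assay on HL-60 cells (Homo sapiens) for inhibition, read by sulforhodamine B assay, with a stated time of 48 h, tested at 10 uM; a lower number here means less inhibition, a higher number more inhibition at the concentration tested (going by the name of the read-out). Compound 1 `COc1ccc(-c2cn3ccnc3c(-c3ccc4ncn(C5CCCCC5)c4c3)n2)cc1` gives 98.6%. Compound 2 `O=Cc1ccc(-c2cn3ccnc3c(-c3ccc4ncn(C5CCCCC5)c4c3)n2)cc1` gives 16.5%, and compound 3 `Fc1ccccc1-c1cn2ccnc2c(-c2ccc3ncn(C4CCCCC4)c3c2)n1` gives 9.3%. The step of a number 82.1 percentage points lower from compound 1 to compound 2 (beyond the scatter) and the step of a number 89.3 percentage points lower from compound 1 to compound 3 (beyond the scatter) are both large, while the step of a number 7.2 percentage points lower from compound 2 to compound 3 (within the scatter) stays within the scatter. Compound 2 therefore stands second highest of the three numbers, indistinguishable from compound 3 and far below compound 1.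

Compound 4 `O=Cc1ccc(-c2cn3ccnc3c(-c3ccc4ncn(Cc5ccccc5)c4c3)n2)cc1` has not yet been measured. It differs from compound 2 in one place: benzyl in place of cyclohexyl on an aromatic nitrogen. Among the compounds with values here, none of the measured steps bears on this position; all three concern the aryl group on the aromatic carbon, and the cyclohexyl on the ring nitrogen is the same in compounds 1, 2 and 3. Within the data shown here, there is thus no measured step from which a direction can be read, and the expectation for compound 4 rests on compound 2 alone, which gives 16.5%. The expected step of a number 1.5 percentage points higher from compound 2 to compound 4 (within the scatter) is none beyond the scatter. Compound 4 is accordingly estimated at 18% in this assay, with a range from 0% to 45%.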

Compound 4, a percentage reported as inhibition, at one concentration (the size of the read-out at that concentration, not a potency): 16.5%
The estimate for compound 4 lay 1.5 percentage points above the measured number; the measured number falls inside the stated range.
By their numbers in this assay, from the lowest: compounds 3, 2 and 4 (each within the scatter of the next); then compound 1.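

Within the data shown here, at the aromatic nitrogen, benzyl in place of cyclohexyl gives no change at the digits printed from compound 2 to compound 4 (within the scatter) in this assay, the first reading at this position, since the earlier compounds all carried cyclohexyl there and differed only in the aryl group on the aromatic carbon. With the 4-formylphenyl group held in place, this position therefore accepts an aromatic six-membered ring with one more carbon in place of a non-aromatic one, with no difference in this read-out at the single concentration tested. No measurement shown here offers an explanation for this result.

From the compounds shown here alone, the reading holds only alongside the 4-formylphenyl group, so it remains open whether benzyl would also leave the number in place on the 4-methoxyphenyl compound, where compound 1 gives 98.6% with cyclohexyl. It is also open how this position would respond to a group of another kind, such as an amine, a carboxylic acid or a longer alkyl chain on the ring nitrogen, since cyclohexyl and benzyl are the only two groups shown there.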